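Bromo on the phenoxy group of compound 3

This account rests on a few compounds, and the source may have more. Where it says the series, first, only, none or still open, it means among the compounds named here.

Of the compounds shown here, three on closely related cores have been measured in a functional assay on HeLa cells (Homo sapiens) for cytotoxicity, read by MTT assay, with a stated time of 48 h (on this read-out higher numbers stand for weaker inhibition and lower numbers for stronger inhibition), so far. Compound 1 (`COc1cc(OC)c(OC)cc1/C=C/C(=O)/C=C/c1cc2ccccc2nc1Cl`) gives 5410 nM and compound 2 (`COc1cc(OC)c(OC)cc1/C=C/C(=O)/C=C/c1cc2ccccc2nc1Oc1ccccc1`) gives 12200 nM in this assay. Compound 3 (`COc1cc(OC)c(/C=C/C(=O)/C=C/c2cc3ccccc3nc2Oc2ccccc2)c(OC)c1`) also carries a phenoxy group and gives > 10000 nM, which is a limit of the assay and not a number. Compound 3 therefore sits at the limit of > 10000 nM in this assay, at which 1 of the 3 values shown sits, so its true position is not known.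

Compound 4 (`COc1cc(OC)c(/C=C/C(=O)/C=C/c2cc3ccccc3nc2Oc2ccc(Br)cc2)c(OC)c1`) differs from compound 3 by bromo in place of hydrogen on an aromatic carbon, para to a large group: bromo in place of hydrogen on an aromatic carbon. The same difference reads phenoxy to 4-bromophenoxy.

Within the data shown here, no measured step covers this change. The only one available is a 2.3-fold higher number from compound 1 to compound 2 (0.35 log units; beyond the scatter), for phenoxy in place of chloro on an aromatic carbon, and it bears on the new change only loosely. As far as these compounds go, a step of about that modest size is the most that can be expected, and its direction stays open. The expected step is a number no higher from compound 3 to compound 4 (the limit leaves the size open), read against a limit only. For compound 4 the estimated value is 10000 nM, with an expected range of 4000 nM to 25000 nM.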

Compound 4, half-maximal inhibitory concentration: > 10000 nM
Compound 4 ended at the assay's limit; the forecaster's own chance of this, stated with the estimate: 35%; the middle value sits exactly at the limit.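

Compound 3 and compound 4 both stand at a limit of the assay and not at a number, so no step can be read between them. The compounds shown leave open how far either compound lies past that limit, and whether bromo on the phenoxy group changes the true value at all.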